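Removing the allyl group from compound 2

This account rests on a few compounds, and the source may have more. Where it says the series, first, only, none or still open, it means among the compounds named here.

Measured compounds:
compound 1 `COc1ccccc1/C=c1/[nH]c(=O)/c(=C\c2ccccc2OC)n(C)c1=O`, 16200 nM
compound 2 `C=CCn1c(=O)/c(=C\c2ccccc2OC)[nH]c(=O)/c1=C\c1ccccc1OC`, 15700 nM

In a functional assay on HL-60 cells (Homo sapiens) for cytotoxicity, read by CCK-8 assay, with a stated time of 72 h (a higher number here means a weaker inhibitor, a lower number a stronger inhibitor), compound 2 gives 15700 nM, the lowest of the two numbers, though its nearest neighbour, compound 1, differs from it only within the scatter. For the measured compounds named here, the one measured step, a 1.0-fold lower number from compound 1 to compound 2 (0.01 log units; within the scatter), shows that exchanging methyl for allyl on the nitrogen leaves the read-out essentially unchanged.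

Compound 3 `COc1ccccc1/C=c1/[nH]c(=O)/c(=C\c2ccccc2OC)[nH]c1=O` is the unmeasured partner. It differs from compound 2 in that (hydrogen in place of allyl on an aromatic nitrogen). That change resembles the measured step in one way: both alter what sits on the same aromatic nitrogen. Going by the values given here, no measured pair, however, shows the substituent replaced by hydrogen. Given that the substituent swap in a 1.0-fold lower number from compound 1 to compound 2 (0.01 log units; within the scatter) produced nothing beyond the scatter, the expected step of a 1.0-fold higher number from compound 2 to compound 3 (0.01 log units; within the scatter) is taken as no change beyond the scatter either, with a wider range to reflect the untested nature of the bare nitrogen.

Compound 3 is therefore estimated at 16000 nM in this assay, with a range from 6000 nM to 45000 nM.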

Compound 3, half-maximal inhibitory concentration: "not active" (no number reported)
The entry for compound 3 holds no number; no gap can be computed for the estimate.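

For the compounds shown here, compound 3 is reported as "not active" in this assay and carries no number, so no step from compound 2 to compound 3 can be read. No evidence here bears on that entry. The compounds shown leave open how far the number for compound 3 would lie from that of compound 2.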